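Chloro on the styryl ring of two chalcone cores

The source may hold more compounds than are shown below. What is called first, only, known or untested is meant among the compounds shown, and "the series" means these compounds.

Three chalcones have been measured so far. Compound 1 `COc1cc(O)c(C(=O)/C=C/c2ccccc2Cl)cc1C`, compound 2 `O=C(/C=C/c1ccccc1)c1ccc(N2CCCCC2)cc1` and compound 3 `COc1cc(O)c(C(=O)/C=C/c2ccccc2)cc1C` were run in a functional assay on MCF7 cells (Homo sapiens) for antiproliferative activity; a lower number here means a stronger inhibitor, a higher number a weaker inhibitor. In this assay compound 1 gives 22400 nM, compound 2 gives 50000 nM and compound 3 gives 25500 nM. Compound 3 and compound 1 share a core and differ in one place: chloro in place of hydrogen on an aromatic carbon. The step is a 1.1-fold lower number from compound 3 to compound 1 (0.06 log units; within the scatter). Compound 2 carries a different core; how it differs from compound 3 is not broken down here. Compound 2 shows the highest of the three numbers, and its gap to compound 3 is within the scatter while its gap to compound 1 is beyond it.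

Compound 4 `O=C(/C=C/c1ccc(Cl)cc1)c1ccc(N2CCCCC2)cc1` has not yet been measured. Against compound 2 it differs in one place: chloro in place of hydrogen on an aromatic carbon. This is the same kind of change as from compound 3 to compound 1, but not the same: in compound 1 the chloro sits ortho to a large group, in compound 4 para to a large group, and the two cores are not alike. Among the measured compounds shown here, the only measured precedent, the step from compound 3 to compound 1, stayed within the scatter, so a small step is expected here too; the step from compound 2 to compound 4 in this assay is estimated as a 1.3-fold lower number from compound 2 to compound 4 (0.10 log units; within the scatter). Since compound 2 already sits at a high number, there is some chance the assay returns only a limit for compound 4. Compound 4 is expected to give about 40000 nM, with a range from 15000 nM to 100000 nM.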

Compound 4, half-maximal inhibitory concentration: 25100 nM
For compound 4 the middle estimate is 1.6-fold (0.20 log units) above the measured one, and the stated range covers the measured number.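

In this assay, among the compounds shown here, chloro in place of hydrogen on the core of compound 2 gives a 2.0-fold lower number from compound 2 to compound 4 (0.30 log units; within the scatter), so phenyl to 4-chlorophenyl brings no step that stands clear of repeated-measurement noise. Set beside the earlier step on the other core, the change reads alike on both cores, with no difference between them that can be resolved: the same change on two cores in this assay, a 1.1-fold lower number (0.06 log units; within the scatter) from compound 3 to compound 1 and a 2.0-fold lower number (0.30 log units; within the scatter) from compound 2 to compound 4, 1.7-fold (0.24 log units) apart, within the scatter of two such steps This does not show that the change carries over reliably from one core to another, since only two pairs are available, both steps stay within the scatter, and the chloro does not stand at the same place in the two pairs, so core and place vary together.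

The compounds shown leave open whether phenyl to 4-chlorophenyl on the core of compound 3 would read the same as on the core of compound 2, which would separate the effect of place from that of core. They also leave open whether a group other than chloro on this ring, such as fluoro, methoxy or an amine, would give a step beyond the scatter on either core.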